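The source may hold more compounds than are shown below. What is called first, only, known or untested is meant among the compounds shown, and "the series" means these compounds.

Of the compounds shown here, two of one shared core have been tested so far, and they differ at two places at once. Compound 1 `CCOc1nc(-c2cc3ccccc3o2)cc(-c2ccc(Cl)cc2)c1C#N` carries an ethoxy group and a chlorophenyl ring, and in a functional assay on aorta (strain Wistar) for inhibition, with Thoracic aorta (Rattus norvegicus) as the target (a higher number here means a weaker inhibitor, a lower number a stronger inhibitor), compound 1 gives 221000 nM. Compound 2 `COc1nc(-c2cc3ccccc3o2)cc(-c2ccc(C)o2)c1C#N` carries a methoxy group and a methylfuranyl ring instead, and in this assay compound 2 gives 285000 nM, a number that does not differ from that of compound 1 beyond the usual scatter of such measurements. Both are weak inhibitors.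

Compound 3 `CCOc1nc(-c2cc3ccccc3o2)cc(-c2ccc(C)o2)c1C#N` is the next compound and has not yet been measured in this assay. It keeps the methylfuranyl ring of compound 2 and changes only one thing: methyl in place of hydrogen on a saturated chain carbon bound to an oxygen on an aromatic ring, so that methoxy becomes ethoxy. Among the compounds with values here, no pair of measured compounds isolates this change, so there is no step to lean on. Compound 1, which already carries ethoxy, sits within the scatter of compound 2, which makes a large move unlikely. The step from compound 2 to compound 3 is expected to be small, a 1.1-fold lower number from compound 2 to compound 3 (0.06 log units; within the scatter), in no firm direction. Compound 3 is therefore expected to give about 250000 nM, with a likely range from 100000 nM to 600000 nM.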

Compound 3, half-maximal inhibitory concentration: 417000 nM
Estimate against measurement, compound 3: 1.7-fold (0.22 log units) below, within the range that was stated.
By their numbers in this assay, from the lowest: compounds 1, 2 and 3 (each within the scatter of the next).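

The change from methoxy to ethoxy now has a step of its own in this assay: a 1.5-fold higher number from compound 2 to compound 3 (0.17 log units; within the scatter). At this saturated chain carbon bound to an oxygen on an aromatic ring, adding a methyl therefore produces no shift that can be told apart from the spread of repeated measurements. With ethoxy held in place, the second step isolates a change at another site, 5-methylfuran-2-yl in place of 4-chlorophenyl on an aromatic carbon, and gives a 1.9-fold higher number from compound 1 to compound 3 (0.28 log units; within the scatter), so this swap of one ring for another also produces no readable shift, and no measurement offered here speaks to the reason behind either step.

The compounds shown leave open whether a longer chain such as butoxy, or a chain ending in an amine or a carboxylic acid, would move the number beyond the scatter at the position that holds methoxy or ethoxy. They also leave open whether any other group on that aromatic carbon, such as a pyridine ring, would give a clearly different number from 4-chlorophenyl or 5-methylfuran-2-yl.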